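Toward the unsubstituted anilide: compound 4 in the series

The compounds below may be only part of what the source reports. "The series", "measured", "known", "first", "only" and "open" are said of these compounds alone.

The measured compounds are: compound 1 `CCOc1ccc(Br)cc1-c1cc(Nc2ccc(C#N)cc2)nc(N)n1`, compound 2 `CCOc1ccc(Br)cc1-c1cc(Nc2ccc(C(=O)NO)cc2)nc(N)n1`, compound 3 `CCOc1ccc(Cl)cc1-c1cc(Nc2ccc(CCCO)cc2)nc(N)n1`. In an assay on Sf9 cells for inhibition of 1-acyl-sn-glycerol-3-phosphate acyltransferase beta (Homo sapiens) (a lower number here means a stronger inhibitor, a higher number a weaker inhibitor), compound 1 gives 17 nM, compound 2 gives 88 nM, and compound 3 gives 230 nM. Compound 2 thus stands second highest of the three numbers, between compound 3 and compound 1.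

Compound 4 `CCOc1ccc(Br)cc1-c1cc(Nc2ccccc2)nc(N)n1` differs from compound 2 by hydrogen in place of hydroxycarbamoyl on an aromatic carbon. Within the data shown here, the only measured step at this position is a 5.2-fold higher number from compound 1 to compound 2 (0.71 log units; beyond the scatter), which shows that a change at this position can move the number beyond the scatter. Among the measured compounds shown here, no measured pair shows removal of the group altogether, so the direction is uncertain; a modest rise is expected, a 1.7-fold higher number from compound 2 to compound 4 (0.23 log units; within the scatter). Compound 4 is therefore estimated at 150 nM, with a range from 40 nM to 600 nM.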

Compound 4, half-maximal inhibitory concentration: 120 nM
Compound 4: middle estimate off by 1.3-fold (0.10 log units), on the high side, within the range that was stated.
By their numbers in this assay, from the lowest: compound 1; then compounds 2, 4 and 3 (each within the scatter of the next, the first and the last beyond it).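

Taking hydrogen as the reference at this aromatic carbon in this assay, a 1.4-fold higher number from compound 2 to compound 4 (0.13 log units; within the scatter) shows that the hydroxycarbamoyl group can leave without a shift beyond the scatter. Against the same reference, a 7.1-fold higher number from compound 1 to compound 4 (0.85 log units; beyond the scatter) shows that the nitrile alone stands apart, so the earlier gap between the two groups reflects a gain with the nitrile, not a loss with hydroxycarbamoyl. No measurement at hand explains what sets the nitrile apart. As far as these compounds go, whether an amine, a carboxylic acid or a methoxy group at this carbon would match the nitrile or hydrogen remains open.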